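The source may report more compounds than this note shows. Statements on the series, on what has been measured and on what is new or still open speak of the compounds shown alone.

The study compares four compounds built on closely related cores. Compound 3, `CCOC(=O)Nc1cc(N/N=C/c2ccccc2)c2[nH]c(S)nc2n1`, carries a sulfanyl group with a hydrogen on its sulfur. Compound 1, `CCOC(=O)Nc1cc(N/N=C/c2ccccc2)c2[nH]c(SCc3ccccc3)nc2n1`, is the same core with benzyl in place of hydrogen on a sulfur. Compound 2, `CCOC(=O)Nc1cc2c(nc(S)n2/N=C/c2ccccc2)c(N)n1`, has the same atoms as compound 3 joined differently; the difference between the two cores is not broken down here. Compound 4, `CCOC(=O)Nc1cc2c(nc(SCc3ccccc3)n2/N=C/c2ccccc2)c(N)n1`, stands to compound 2 as compound 1 stands to compound 3, carrying (benzyl in place of hydrogen on a sulfur).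

In a functional assay on L1210 cells (Mus musculus) for inhibition (a lower number here means a stronger inhibitor, a higher number a weaker inhibitor), compound 3 gives 1500 nM. In this assay compound 1 gives 46000 nM, so the benzyl step brings a 31-fold higher number from compound 3 to compound 1 (1.49 log units; beyond the scatter). In this assay compound 2 gives 470 nM, the lowest of the three measured numbers and beyond the scatter from both others.

Compound 4 has not yet been measured. The change it carries relative to compound 2 is the same change as that from compound 3 to compound 1: in both cases the place is a sulfur whose other neighbour is an aromatic carbon. Within the data shown here, the only guide is that single measured step; the two cores differ, and nothing measured shows whether the step carries over unchanged. In this assay the expected step is a 28-fold higher number from compound 2 to compound 4 (1.44 log units; beyond the scatter), close in size to the earlier one. Compound 4 is therefore estimated at 13000 nM in this assay, with a likely range from 3500 nM to 45000 nM.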

Compound 4, half-maximal inhibitory concentration: 50000 nM
Beside the measured number, compound 4's estimate is 3.8-fold (0.59 log units) below it; the whole stated range lies below it.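

On the second core, benzyl in place of hydrogen on a sulfur brings a 110-fold higher number from compound 2 to compound 4 (2.03 log units; beyond the scatter) in this assay, so the change again goes with weaker inhibition. The direction of the change carries over from one core to the other, but its size does not: the same change on two cores in this assay, a 31-fold higher number (1.49 log units; beyond the scatter) from compound 3 to compound 1 and a 110-fold higher number (2.03 log units; beyond the scatter) from compound 2 to compound 4, 3.5-fold (0.54 log units) apart, beyond the scatter of two such steps

This rests on a single pair of compounds for each core, so it shows that the size of the step on one core need not hold on the other, but it does not show why the two steps differ or how the change would behave on any further core.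

The compounds shown carry only hydrogen or benzyl on the sulfur, so they leave open whether methyl, a longer chain such as phenethyl, or a benzyl group bearing a chlorine or a methoxy group would bring a step as large on either core. They also leave open whether a chain ending in an amine or a carboxylic acid on that sulfur would follow the same direction on both cores, and whether the gap between the two steps would remain.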